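The compounds below may be only part of what the source reports. "The series", "measured", "known", "first", "only" and "open" are said of these compounds alone.

Measured in a functional assay on BCG823 cells (Homo sapiens) for cytotoxicity, read by MTT assay, with a stated time of 72 h; a lower number here means a stronger inhibitor, a higher number a weaker inhibitor:
- Compound 1 `COC(=O)C(COC(=O)/C=C/c1ccc(OC)c(OC)c1)c1ccccc1`: > 0.01 ug/mL (a limit)
- Compound 2 `CCOC(=O)C(COC(=O)c1ccccc1OC(C)=O)c1ccc(F)cc1`: > 0.01 ug/mL (a limit)

Compound 2 has no number, only a limit, and it shares that limit with compound 1: the limit of > 0.01 ug/mL in this assay, at which 2 of the 2 values shown sit. Compound 3 `CCOC(=O)C(COC(=O)c1ccccc1OC(C)=O)c1ccc(C(F)(F)F)cc1` departs from compound 2 by trifluoromethyl in place of fluoro on an aromatic carbon, with trifluoromethyl in place of fluoro on an aromatic carbon, para to a large group. With only limits in hand, no step beyond the scatter and no direction is expected. The estimated step that the limit leaves unreadable from compound 2 to compound 3 is expected to stay small. For compound 3 the expected value is 0.02 ug/mL, with an estimated range of 0.005 ug/mL to 0.1 ug/mL.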

Compound 3, half-maximal inhibitory concentration: > 0.01 ug/mL
Compound 3 ended at the assay's limit; the forecaster's own chance of this, stated with the estimate: 80%; the middle value does not contradict the limit.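

No step can be read between compound 2 and compound 3, because each value is only a limit: the limit of > 0.01 ug/mL in this assay, at which 3 of the 3 values shown sit.

As far as these compounds go, whether trifluoromethyl in place of fluoro alters cytotoxicity at all, and how compound 1, compound 2 and compound 3 rank, stays open.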